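Isopropyl for Methyl on the Ring Nitrogen

The source may report more compounds than this note shows. Statements on the series, on what has been measured and on what is new or still open speak of the compounds shown alone.

compound 1 `CCOC(=O)c1ccc(OC(=O)c2ccc3c(c2)C(C)(C)CCN3C)cc1`: 256 nM
compound 2 `CCOC(=O)c1ccc(OC(=O)c2cc3c(cc2C)N(C)CCC3(C)C)cc1`: 92 nM

In a functional assay on CV-1 cells for activation of retinoic acid receptor beta (Homo sapiens) (on this read-out lower numbers stand for an effect already at smaller amounts and higher numbers for an effect only at larger amounts of compound), compound 1 gives 256 nM, the highest of the two numbers; the nearest is compound 2, reached by a 2.8-fold lower number from compound 1 to compound 2 (0.44 log units; beyond the scatter). Compound 3 `CCOC(=O)c1ccc(OC(=O)c2ccc3c(c2)C(C)(C)CCN3C(C)C)cc1` differs from compound 1 by isopropyl in place of methyl on a nitrogen on an aromatic ring in a ring. Within the data shown here, the one measured step, a 2.8-fold lower number from compound 1 to compound 2 (0.44 log units; beyond the scatter), concerns a methyl on an aromatic carbon and leaves the ring nitrogen untouched, so no measured step bears on this change. Compound 3 is expected to stay close to compound 1 in this assay, with no step beyond the scatter, a 1.0-fold lower number from compound 1 to compound 3 (0.01 log units; within the scatter). The estimate for compound 3 is 250 nM, between 80 nM and 800 nM.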

Compound 3, half-maximal effective concentration: 41 nM
Beside the measured number, compound 3's estimate is 6.1-fold (0.79 log units) above it; the whole stated range lies above it.
By their numbers in this assay, from the lowest: compound 3; then compound 2; then compound 1.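

Among these compounds, the ring nitrogen turns out to be a place where the substituent matters in this assay and where the earlier compounds offered no test: isopropyl in place of methyl gives a 6.2-fold lower number from compound 1 to compound 3 (0.80 log units; beyond the scatter) and so moves the number beyond the scatter. The added size of the group thus goes with a lower number here, in this single pair. Nothing available on these compounds explains the step.

As far as these compounds go, only methyl and isopropyl appear on this nitrogen, so it remains open whether ethyl or a longer chain would lower the number further. Also open, from the compounds shown here alone, is whether isopropyl there and the methyl on the aromatic carbon of compound 2 would add up in one molecule.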